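A few compounds are considered here, and "the series" means these few. Any claim that something is new, unique, unknown or untested is made for them only; others in the source may bear on it.

Measured in a functional assay on A-375 cells (Homo sapiens) for antiproliferative activity, read by MTT assay, with a stated time of 72 h; on this read-out higher numbers stand for weaker inhibition and lower numbers for stronger inhibition:
- compound 1 `COc1cccc(N2C(=O)COc3ccc(-c4cnc5ccccc5c4)cc32)c1`: 23600 nM
- compound 2 `O=C1COc2ccc(-c3cnc(Cl)c(NS(=O)(=O)c4ccc(F)cc4)c3)cc2N1c1ccc(F)cc1`: > 40000 nM, a limit
- compound 3 `CC(C)N1C(=O)COc2ccc(-c3cccc(NS(=O)(=O)c4ccc(F)cc4)c3)cc21`: > 40000 nM, a limit

Compound 1 is the only one of the three with an actual number. Compound 2 and compound 3 give only a limit: the limit of > 40000 nM in this assay, at which 2 of the 3 values shown sit.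

Compound 4 `O=C1COc2ccc(-c3cnc4ccccc4c3)cc2N1C1CCCCC1` keeps the core of compound 1 and changes one group, with cyclohexyl in place of 3-methoxyphenyl on an amide-type nitrogen in a ring. Among the measured compounds shown here, no measured pair shows this change on its own, so no step beyond the scatter is expected in this assay, in either direction. The estimated change is a 1.1-fold higher number from compound 1 to compound 4 (0.03 log units; within the scatter). A result reported only as a limit is also possible. For compound 4 the expected value is 25000 nM, with an estimated range of 11000 nM to 40000 nM.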

Compound 4, half-maximal inhibitory concentration: > 40000 nM
Compound 4: only a limit was reported; the forecaster's own chance of this, stated with the estimate: 35%; middle value at least 1.6-fold (0.20 log units) from the limit.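

Placing cyclohexyl in place of 3-methoxyphenyl on the amide-type nitrogen gives the first one-place comparison at this position: in this assay the result is an at least 1.6-fold higher number from compound 1 to compound 4 (0.22 log units; that floor lies within the scatter). Compound 4 gives only a limit, so the full size of this step cannot be read, and its floor alone does not establish a real loss. Cyclohexyl gives no measurable value here, and compound 4 joins the compounds at the same limit: the limit of > 40000 nM in this assay, at which 3 of the 4 values shown sit.

As far as these compounds go, whether a methyl group or a chain ending in an amine or a carboxylic acid on this nitrogen would give a measurable value remains open.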